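A Bromine Moves Round the Ring on a Shared Core

This account rests on a few compounds, and the source may have more. Where it says the series, first, only, none or still open, it means among the compounds named here.

Of the compounds shown here, three have been tested in a functional assay on HCT-116 cells (Homo sapiens) for antiproliferative activity, read by MTT assay, with a stated time of 48 h; on this read-out higher numbers stand for weaker inhibition and lower numbers for stronger inhibition. Compound 1 `N#CC1=C(N)Oc2c(c3nc4ccccc4nc3c3ccccc23)C12C(=O)N(Cc1cnnn1-c1ccccc1Br)c1ccccc12` gives > 50000 nM in this assay, which is a limit of the assay and not a measured number. Compound 2 `N#CC1=C(N)Oc2c(c3nc4ccccc4nc3c3ccccc23)C12C(=O)N(Cc1cnnn1-c1cccc(Br)c1)c1ccccc12` likewise gives > 50000 nM in this assay, again a limit rather than a number. The two differ in one place, (2-bromophenyl in place of 3-bromophenyl on an aromatic nitrogen), and the step that the two limits leave unreadable from compound 2 to compound 1 cannot be sized because of the limit of > 50000 nM in this assay, at which 2 of the 3 values shown sit.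

Compound 3 `N#CC1=C(N)Oc2c(N)cc3nc4ccccc4nc3c2C12C(=O)N(Cc1cnnn1-c1cccc(Br)c1)c1ccccc12` is the only one of the three with a measured number: in this assay compound 3 gives 26100 nM. How the core of compound 3 differs from the core of compound 2 is not broken down here.

Compound 4 `N#CC1=C(N)Oc2c(N)cc3nc4ccccc4nc3c2C12C(=O)N(Cc1cnnn1-c1ccccc1Br)c1ccccc12` has not yet been measured. It differs from compound 3 by 2-bromophenyl in place of 3-bromophenyl on an aromatic nitrogen, the same change as from compound 2 to compound 1, at the same place in the same words. Since the measured example of this change gives no readable size, any expectation for compound 4 rests on compound 3 alone with its value of 26100 nM. The step is expected to be a 1.1-fold higher number from compound 3 to compound 4 (0.06 log units; within the scatter), close to no change. Compound 4 is therefore expected to give about 30000 nM in this assay, within a range from 10000 nM to 90000 nM, with a real chance that the assay returns only a limit.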

Compound 4, half-maximal inhibitory concentration: 12400 nM
Compound 4: middle estimate off by 2.4-fold (0.38 log units), on the high side, and the stated range covers the measured number.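

Swapping 3-bromophenyl for 2-bromophenyl in this assay gives a 2.1-fold lower number from compound 3 to compound 4 (0.32 log units; beyond the scatter) and so a modest gain in inhibition on this one core, a step that lies beyond the usual scatter of repeated measurements. This shows that the change can shift the read-out on the core that carries it here, but one readable step on one core cannot show that the change carries from one core to another, nor that it would keep its direction or size elsewhere. The matching step on the core shared by compound 1 and compound 2 cannot be read, so it neither supports nor contradicts the new step, because both compounds give only a limit and not a measured number: the limit of > 50000 nM in this assay, at which 2 of the 4 values shown sit.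

The compounds shown leave open whether the step belongs to bromine in particular, since nothing here compares it with chlorine, a methoxy group or a plain phenyl ring without any bromine on the triazole. They also leave open whether a third core, or an amine or a carboxylic acid on the phenyl ring, would give values clear of the limit, so that the same swap could be sized on more than one core.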